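The source may hold more compounds than are shown below. What is called first, only, known or untested is meant among the compounds shown, and "the series" means these compounds.

Measured so far in a functional assay on HepG2 cells (Homo sapiens) for inhibition, read by MTT assay, with a stated time of 72 h; a higher number here means a weaker inhibitor, a lower number a stronger inhibitor:
Compound 1 `CCCNC(=O)c1ccc(Oc2nc(-c3c(C)noc3C)cnc2N)cc1` gives 6880 nM.
Compound 2 `Cc1noc(C)c1-c1cnc(N)c(Oc2ccc(C(=O)NC3CC3)cc2)n1` gives 43200 nM.
Compound 3 `Cc1noc(C)c1-c1cnc(N)c(Oc2ccc(C(=O)Nc3cc(Cl)ccn3)cc2)n1` reaches only the limit of the assay, > 100000 nM, so no number is known for it.

Compound 3 therefore stands as the weakest of the three, since its steps from both other compounds lie beyond the scatter; in this assay (the limit of > 100000 nM in this assay, at which 1 of the 3 values shown sits), and compound 3 is that one. All three measured steps change the group on the amide-type nitrogen: a 6.3-fold higher number from compound 1 to compound 2 (0.80 log units; beyond the scatter), an at least 14-fold higher number from compound 1 to compound 3 (1.16 log units; beyond the scatter), and an at least 2.3-fold higher number from compound 2 to compound 3 (0.36 log units; beyond the scatter). Compound 4 `Cn1cc(-c2cnc(N)c(Oc3ccc(C(=O)Nc4cc(Cl)ccn4)cc3)n2)cn1` keeps the whole amide side of compound 3 unchanged and differs at another place: 1-methyl-1H-pyrazol-4-yl in place of 3,5-dimethyl-1,2-oxazol-4-yl on an aromatic carbon. Going by the values given here, none of the measured steps touches this position, so they give no direct guide to the size or direction of this change. Among the compounds with values here, with compound 3 already at the limit and no measured step bearing on the change, the expectation is that compound 4 stays at or near that limit. The estimated step is a number no higher from compound 3 to compound 4 (the limit leaves the size open). The estimate for compound 4 in this assay is 100000 nM, with a range from 30000 nM to 300000 nM.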

Compound 4, half-maximal inhibitory concentration: > 100000 nM
Compound 4: only a limit was reported (the forecaster's own chance of this, stated with the estimate: 70%); the middle value lies on the limit itself.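

Compound 3 and compound 4 each reach only a limit, not a number, so in this assay the step between them cannot be read: the limit of > 100000 nM in this assay, at which 2 of the 4 values shown sit. The compounds shown leave open whether 1-methyl-1H-pyrazol-4-yl in place of 3,5-dimethyl-1,2-oxazol-4-yl changes the number at all, and in which direction.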